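Swapping the amine on a dithiocarbamate: compound 1 to compound 3

The compounds below may be only part of what the source reports. "The series", "measured", "known", "first", "only" and "open" are said of these compounds alone.

Measured compounds:
compound 1, `Nc1ccccc1NC(=O)c1ccc(CSC(=S)N2CCc3ccccc32)cc1`, 87%
compound 2, `COc1ccc(N2CCN(C(=S)SCc3ccc(C(=O)Nc4ccccc4N)cc3)CC2)cc1`, 22.9%

Of the compounds shown here, two have been tested in a functional assay on MGC-803 cells (Homo sapiens) for antiproliferative activity, read by CCK-8 assay, with a stated time of 72 h, tested at 8 uM; a higher number here means a stronger effect of the compound at the concentration tested, a lower number a weaker effect. Compound 1 gives 87%, the highest of the two numbers. Compound 2 gives 22.9%, and the gap between these two values lies beyond the usual scatter, so compound 1 stands clearly above compound 2.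

Compound 3, `CC1CCN(C(=S)SCc2ccc(C(=O)Nc3ccccc3N)cc2)CC1`, has not yet been measured. It differs from compound 1 in one place: 4-methylpiperidin-1-yl in place of 2,3-dihydro-1H-indol-1-yl on a thiocarbonyl carbon. Among the measured compounds shown here, no step between two measured compounds isolates this change, since compound 2 differs from compound 1 in a different amine on the thiocarbonyl carbon, so the direction for compound 3 can only be judged loosely. The step is expected to be a decrease of moderate size, likely beyond the scatter, a number 22 percentage points lower from compound 1 to compound 3 (beyond the scatter). For compound 3 the estimate is 65%, with a range from 30% to 90%.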

Compound 3, a percentage reported as inhibition, at one concentration (the size of the read-out at that concentration, not a potency): 81.9%
The estimate for compound 3 lay 16.9 percentage points below the measured number, and the stated range covers the measured number.
By their numbers in this assay, from the lowest: compound 2; then compounds 3 and 1 (each within the scatter of the next).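

In this assay, among the compounds shown here, the exchange of 2,3-dihydro-1H-indol-1-yl for 4-methylpiperidin-1-yl on the thiocarbonyl carbon reads as a number 5.1 percentage points lower from compound 1 to compound 3 (within the scatter) and so gives the first one-place step at this position: in this pair, the six-membered aromatic ring of carbon only that leaves with 2,3-dihydro-1H-indol-1-yl is not needed to keep the read-out, and an amine with one non-aromatic ring serves as well. The position is still not indifferent to the amine it carries, since compound 2, with another amine at the same place, gives 22.9% in this assay and stands well apart from the other two. No measurement shown here explains why these amines behave as they do.

The compounds shown leave open whether an open-chain amine such as diethylamine, or a ring holding oxygen such as morpholine, would keep the read-out at this place. With a single tested concentration, they also leave open whether compound 1 and compound 3 would match in potency.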